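The source may report more compounds than this note shows. Statements on the series, on what has been measured and on what is new or still open speak of the compounds shown alone.

Working notes on the series.

The shared core carries a urea-linked aryl group, and the compounds differ only in that aryl ring. Compound 1 `COc1cc(NC(C)CCCNC(=O)NNC(=O)Nc2ccc(Cl)cc2)c2ncccc2c1` gives in a functional assay on MIA PaCa-2 cells (Homo sapiens) for inhibition, read by MTT assay, with a stated time of 72 h (a higher number here means a weaker inhibitor, a lower number a stronger inhibitor), a value that is an assay limit rather than a number: >= 250000 nM. Compound 2 `COc1cc(NC(C)CCCNC(=O)NNC(=O)Nc2ccc(C(F)(F)F)cc2)c2ncccc2c1` gives 19000 nM. Compound 3 `COc1cc(NC(C)CCCNC(=O)NNC(=O)Nc2ccc(Br)cc2)c2ncccc2c1` gives 231000 nM, the highest of the two actual numbers, with compound 2 as its nearest neighbour. The step of a 12-fold higher number from compound 2 to compound 3 (1.08 log units; beyond the scatter) is large; the step of an at least 13-fold lower number from compound 1 to compound 2 (1.11 log units; beyond the scatter) is also large, while an at least 1.0-fold lower number from compound 1 to compound 3 (0.03 log units; that floor lies within the scatter) rests on the limit of >= 250000 nM in this assay, at which 1 of the 3 values shown sits, and says little.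

Compound 4 `COc1cc(NC(C)CCCNC(=O)NNC(=O)Nc2cccc(C(F)(F)F)c2)c2ncccc2c1` is not yet measured. Its difference from compound 3 is 3-(trifluoromethyl)phenyl in place of 4-bromophenyl on an amide-type nitrogen. This change bears two parts: the halogen gives way to trifluoromethyl, and the substituent moves from the 4-position to the 3-position of the phenyl. The first part is covered by a 12-fold higher number from compound 2 to compound 3 (1.08 log units; beyond the scatter) run in reverse, a large step toward lower numbers. Among the measured compounds shown here, the second part has no counterpart among the measured compounds, so its size is unknown. On these data alone, the expectation is therefore a step toward a lower number, estimated as a 5.8-fold lower number from compound 3 to compound 4 (0.76 log units; beyond the scatter), but with wide uncertainty because the positional shift is untested. Compound 4 is estimated at 40000 nM, within 10000 nM to 200000 nM.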

Compound 4, half-maximal inhibitory concentration: 5600 nM
Compound 4: middle estimate off by 7.1-fold (0.85 log units), on the high side, and the stated range ends above it.
By their numbers in this assay, from the lowest: compound 4; then compound 2; then compound 3. At a limit, above all of these: compound 1.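

Among the compounds shown here, the step of a 3.4-fold lower number from compound 2 to compound 4 (0.53 log units; beyond the scatter) is modest but beyond the scatter, and it isolates what the earlier compounds could not address: in this assay, 3-(trifluoromethyl)phenyl and 4-(trifluoromethyl)phenyl are not equivalent, so the place of the group on the phenyl counts as well as its identity. The larger step of a 41-fold lower number from compound 3 to compound 4 (1.62 log units; beyond the scatter) joins that shift to the exchange of bromo for trifluoromethyl, and both parts run toward lower numbers in this series. For compound 1 the value is a limit and not a number, so an at least 44-fold lower number from compound 1 to compound 4 (1.64 log units; beyond the scatter) is only a floor: the limit of >= 250000 nM in this assay, at which 1 of the 4 values shown sits.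

Whether the gain seen on going from 4-(trifluoromethyl)phenyl to 3-(trifluoromethyl)phenyl carries over to the halogens stays open, since a pair such as 3-bromophenyl and 4-bromophenyl is not among the compounds shown. On these data alone, how a nitrile, an amine or a carboxylic acid on the phenyl would compare with trifluoromethyl also remains unknown, as does the effect of changing the chain of the shared core.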